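The compounds below may be only part of what the source reports. "The series", "measured", "known", "first", "only" and "open" are said of these compounds alone.

Measured compounds:
- compound 1 `COC(=O)[C@@]1(C)CCC=C2[C@@H]1CC[C@@H](C)[C@]2(C)Cc1c(C)[nH]c2ccccc12`: 11000 nM
- compound 2 `COC(=O)[C@@]1(C)CCC=C2[C@@H]1CC[C@@H](C)[C@]2(C)Cc1c(C)[nH]c2ccc(C)cc12`: 17000 nM
- compound 3 `COC(=O)[C@@]1(C)CCC=C2[C@@H]1CC[C@@H](C)[C@]2(C)Cc1c(C)[nH]c2ccc(Br)cc12`: 11000 nM

In a functional assay on HeLa cells (Homo sapiens) for inhibition, read by sulforhodamine B assay, with a stated time of 48 h (a lower number here means a stronger inhibitor of growth, a higher number a weaker inhibitor of growth), compound 1 gives 11000 nM, level with compound 3 at the digits shown, and the two share the lowest number of the three. The nearest neighbour of compound 1 is compound 3, with no change at the digits printed from compound 1 to compound 3 (within the scatter); the furthest is compound 2, with a 1.5-fold higher number from compound 1 to compound 2 (0.19 log units; within the scatter). Between the two substituted analogues there is a 1.5-fold lower number from compound 2 to compound 3 (0.19 log units; within the scatter). Every step among these three therefore stays inside the usual scatter.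

Compound 4 `COC(=O)[C@@]1(C)CCC=C2[C@@H]1CC[C@@H](C)[C@]2(C)Cc1c(C)[nH]c2c(Cl)cccc12` has not yet been measured. It differs from compound 1 by chloro in place of hydrogen on an aromatic carbon. Among the measured compounds shown here, the steps that bear on this change are the substitutions on the same aromatic ring in compound 1 to compound 2 and compound 1 to compound 3, both small halogen-sized or methyl-sized additions, and neither moved the number beyond the scatter. On that basis compound 4 is expected to show no step beyond the scatter in this assay, the expected step being no change at the digits printed from compound 1 to compound 4 (within the scatter). The estimate for compound 4 is 11000 nM, with a range from 5000 nM to 25000 nM.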

Compound 4, concentration for 50% growth inhibition: 17000 nM
Estimate against measurement, compound 4: 1.5-fold (0.19 log units) below; measured number inside the range.
By their numbers in this assay, from the lowest: compounds 1, 3, 2 and 4 (each within the scatter of the next).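

In this assay, chloro on the aromatic carbon that is ortho to a fused ring and meta to a fused ring gives a 1.5-fold higher number from compound 1 to compound 4 (0.19 log units; within the scatter). The earlier steps shown here, with methyl in compound 2 and bromo in compound 3, both concerned a different carbon of the same aromatic ring, so this result extends the picture of a small substituent leaving the number within the scatter to a second place on that ring. Nothing measured here accounts for this result.

The compounds shown leave open whether this carbon would respond the same way to a group other than chloro, such as an amine or a carboxylic acid. They also leave open whether any change to the aromatic ring can move the number beyond the scatter, since all four values remain close together.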